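Swapping a branched side chain for a hydroxyethyl group

The compounds below may be only part of what the source reports. "The series", "measured", "known", "first", "only" and "open" are said of these compounds alone.

Measured so far in a functional assay on the whole organism (Tail, strain ICR) with Mus musculus as the target, in the tail flick test, with a stated time of 90 min, at a dose of 25 umol/kg by the oral route; a lower number here means a weaker effect, a higher number a stronger effect of the compound at the dose given:
Compound 1 `CC[C@H](C)[C@H](NC(=O)CN(c1nc(Cl)nc2[nH]cnc12)C1CC1)C(=O)OCc1ccccc1` gives 36.3%.
Compound 2 `O=C(CN(c1nc(Cl)nc2[nH]cnc12)C1CC1)NCC(=O)OCc1ccccc1` gives 27.2%.
Compound 3 `CC(C)C[C@H](NC(=O)CN(c1nc(Cl)nc2[nH]cnc12)C1CC1)C(=O)OCc1ccccc1` gives 15.2%.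

Compound 3 stands lowest of the three. Both steps leading to it, a number 21.1 percentage points lower from compound 1 to compound 3 (beyond the scatter) and a number 12 percentage points lower from compound 2 to compound 3 (beyond the scatter), lie beyond the scatter, so compound 3 is the weakest compound measured here, while the step of a number 9.1 percentage points lower from compound 1 to compound 2 (within the scatter) stays within the scatter.

Compound 4 `C[C@@H](O)[C@H](NC(=O)CN(c1nc(Cl)nc2[nH]cnc12)C1CC1)C(=O)OCc1ccccc1` differs from compound 3 in one place: 1-hydroxyethyl in place of isobutyl on a saturated chain carbon bound to an amide-type nitrogen and a carbonyl carbon. Going by the values given here, no measured step exchanges a side chain for one carrying a hydroxyl, so none bears directly on this change. What the three measured steps do show is that the group on this carbon matters by modest amounts: removing isobutyl altogether, as in the step of a number 12 percentage points lower from compound 2 to compound 3 (beyond the scatter) read backwards, lifted the read-out, and a group that is smaller than isobutyl by the count given enters here. Compound 4 is therefore expected to sit somewhat above compound 3, with the step of a number 11.8 percentage points higher from compound 3 to compound 4 (beyond the scatter) as the estimate, though the hydroxyl leaves the direction uncertain. For compound 4 the estimated value is 27%, within a range from 12% to 44%.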

Compound 4, a percentage reported as activity, at one dose (the size of the read-out at that dose, not a potency): 29.9%
For compound 4 the middle estimate is 2.9 percentage points below the measured one, and the stated range covers the measured number.
By their numbers in this assay, from the lowest: compound 3; then compounds 2, 4 and 1 (each within the scatter of the next).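

In this assay, placing 1-hydroxyethyl in place of isobutyl on the saturated chain carbon bound to an amide-type nitrogen and a carbonyl carbon gives a number 14.7 percentage points higher from compound 3 to compound 4 (beyond the scatter) and shows that the low read-out of compound 3 is not shared by a side chain carrying a hydroxyl. The other two new steps, a number 2.7 percentage points higher from compound 2 to compound 4 (within the scatter) and a number 6.4 percentage points lower from compound 1 to compound 4 (within the scatter), both stay within the scatter, so the 1-hydroxyethyl, hydrogen and sec-butyl groups cannot be told apart at this position, and isobutyl alone stands apart rather than marking the end of a trend with group size. No supporting data are available to explain why isobutyl differs from the other three groups.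

The compounds shown leave open what an amine, a carboxylic acid or a longer chain would do on this carbon, and whether 1-hydroxyethyl with the opposite arrangement at its defined stereocentre would read the same. These read-outs also come from one dose and one time point, so they describe the size of the effect under those conditions and give no potency for any of the four compounds.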